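A few compounds are considered here, and "the series" means these few. Any claim that something is new, unique, unknown or untested is made for them only; others in the source may bear on it.

Compound 1 `CCOC(=O)C1=C(Nc2ccccc2)S/C(=C\c2cc(OC)ccc2OC)C1=O` and compound 2 `CCOC(=O)C1=C(Nc2ccc(F)cc2)S/C(=C\c2ccc[nH]2)C1=O` share one core and differ in two places. In a functional assay on JAR cells (Homo sapiens) for inhibition, read by MTT assay, with a stated time of 72 h, tested at 10 uM (a higher number here means more inhibition at the concentration tested (going by the name of the read-out), a lower number less inhibition), compound 1 gives 38.1%, while compound 2 gives 61.5%, the higher of the two numbers, and its gap to compound 1 lies beyond the usual scatter. Compound 3 `CCOC(=O)C1=C(Nc2ccc(CC)cc2)S/C(=C\c2ccc[nH]2)C1=O` has not yet been tested; it differs from compound 2 in one respect: ethyl in place of fluoro on an aromatic carbon. Among the measured compounds shown here, no measured pair shows this change, so the expected step is small, at most a slight fall near the edge of the scatter, as a number 7.5 percentage points lower from compound 2 to compound 3 (within the scatter). Compound 3 is therefore estimated to give 54%, probably between 34% and 74%.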

Compound 3, a percentage reported as inhibition, at one concentration (the size of the read-out at that concentration, not a potency): < 10%
Compound 3: only a limit was reported (the forecaster's own chance of this, stated with the estimate: 2%); middle value at least 44 percentage points away from the limit.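

In this assay, putting ethyl in place of fluoro on this aromatic carbon is far from a neutral swap, with a step of a number at least 51.5 percentage points lower from compound 2 to compound 3 (beyond the scatter). Compound 1 and compound 2 differ in two places and could not isolate any single position, whereas this pair shows that this one position alone can change the reading strongly. For compound 3 the reading is a limit, not a number: the limit of < 10% in this assay, at which 1 of the 3 values shown sits.

As far as these compounds go, whether a methyl, a methoxy or a chlorine at this place would keep the reading close to that of compound 2 remains open. From the compounds shown here alone, how much inhibition compound 3 actually gives also stays unknown.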